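Following compound 3 to its chloropiperidine analogue

This account rests on a few compounds, and the source may have more. Where it says the series, first, only, none or still open, it means among the compounds named here.

In an ADME assay (liver) for metabolic stability, with Liver microsome (Homo sapiens) as the target, using microsomes (on this read-out higher numbers stand for a longer-lived compound and lower numbers for a shorter-lived compound), compound 1 (`CC(C)c1nc2ccccn2c1C(=O)NCc1ccc(-c2ccccc2)cc1`) gives 0.527 h and compound 2 (`CCc1nc2ccc(Cl)cn2c1C(=O)NCc1ccc(-c2ccc(C)cc2)cc1`) gives 0.508 h. These two values lie within the scatter of each other.

Compound 3 (`CCc1nc2cc(Cl)ccn2c1C(=O)NCc1ccc(-c2ccc[nH]2)cc1`) gives > 2 h, which is a limit of the assay and not a number. Among the measured compounds shown here, the series so far has one compound at that limit: the limit of > 2 h in this assay, at which 1 of the 3 values shown sits. Compound 3 therefore has no exact half-life to serve as a starting point, only a floor that lies beyond the numbers for compound 1 and compound 2.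

Compound 4 (`CCc1nc2cc(Cl)ccn2c1C(=O)NCc1ccc(N2CCC(Cl)CC2)cc1`) keeps the rest of compound 3 and carries 4-chloropiperidin-1-yl in place of 1H-pyrrol-2-yl on an aromatic carbon, para to a large group (4-chloropiperidin-1-yl in place of 1H-pyrrol-2-yl on an aromatic carbon).

For the measured compounds named here, no measured pair differs in one place only, so the size of this change in this assay has no direct precedent. Going by the values given here, the two exact numbers, from compound 1 at 0.527 h and compound 2 at 0.508 h, are the only guide to where a compound with an exact half-life falls. A shorter half-life is therefore expected, though the compound may stay well clear of those two values. The estimated step, a modest one towards shorter half-life, is an at least 2.2-fold lower number from compound 3 to compound 4 (0.34 log units; beyond the scatter).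

For compound 4 the estimate is 0.9 h, with an expected range of 0.35 h to 2 h.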

Compound 4, half-life: 0.183 h
For compound 4 the middle estimate is 4.9-fold (0.69 log units) above the measured one; measured number below the stated range.
By their numbers in this assay, from the lowest: compound 4; then compounds 2 and 1 (each within the scatter of the next). At a limit, above all of these: compound 3.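

In this assay, the change on an aromatic carbon, para to a large group, now has a measured size: an at least 10-fold lower number from compound 3 to compound 4 (1.03 log units; beyond the scatter). Among the compounds shown here, this is the first step between compounds that differ in one place, and it shows that half-life in this assay can move far on the group at this position alone, with 4-chloropiperidin-1-yl in place of 1H-pyrrol-2-yl taking the series from a limit to an exact number. Compound 3 gives > 2 h, which is a limit of the assay and not a number, so the step marks only a floor on the size of the change, and the series still holds a single value of this kind: the limit of > 2 h in this assay, at which 1 of the 4 values shown sits.

The two groups differ at once in ring size, aromatic character, the chlorine and the hydrogen-bond donor, so this one step does not tell which of these differences goes with the shorter half-life. A plain piperidin-1-yl or a morpholin-4-yl at the same position would help to separate the contribution of the chlorine from that of the non-aromatic ring.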